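Aryl sulfonate amides and a urea analogue on breast cancer cells

The source may hold more compounds than are shown below. What is called first, only, known or untested is meant among the compounds shown, and "the series" means these compounds.

Measured compounds:
compound 1 `CC(C)c1ccccc1OS(=O)(=O)c1cccc(NC(=O)CCl)c1` gives 2200 nM
compound 2 `CC(C)C(=O)Nc1ccc(S(=O)(=O)Oc2ccccc2C(C)C)cc1` gives 8600 nM
compound 3 `CC(C)C(=O)Nc1ccc(S(=O)(=O)Oc2ccccc2I)cc1` gives 8100 nM

The three compounds share an aryl sulfonate core and were tested in a functional assay on MCF7 cells (Homo sapiens) for antiproliferative activity, read by sulforhodamine B assay, with a stated time of 48 h; a lower number here means a stronger inhibitor, a higher number a weaker inhibitor. Compound 3 stands second highest of the three numbers; its nearest neighbour is compound 2, and the step of a 1.1-fold lower number from compound 2 to compound 3 (0.03 log units; within the scatter) lies within the scatter. Compound 1 sits furthest away with the lowest number, but compound 1 differs from compound 3 in more than one place, so only the two values themselves can be compared.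

Compound 4 `CCCCCNC(=O)Nc1ccc(S(=O)(=O)Oc2ccccc2I)cc1` has not been measured. It differs from compound 3 by pentylamino in place of isopropyl on a carbonyl carbon. Within the data shown here, none of the measured steps touches this carbonyl substituent; the single measured step concerns the aromatic ring. There is therefore no measured basis for a directed expectation, and compound 4 is expected to give a number close to that of compound 3, within the scatter, with the step of a 1.1-fold lower number from compound 3 to compound 4 (0.03 log units; within the scatter) as the estimate. For compound 4 the expected value is 7500 nM, with a range from 2500 nM to 22000 nM.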

Compound 4, half-maximal inhibitory concentration: 5400 nM
Compound 4: middle estimate off by 1.4-fold (0.14 log units), on the high side; the measured number falls inside the stated range.
By their numbers in this assay, from the lowest: compound 1; then compounds 4, 3 and 2 (each within the scatter of the next).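

This is the first change shown at the carbonyl substituent, and in this assay the step is a 1.5-fold lower number from compound 3 to compound 4 (0.18 log units; within the scatter). With the iodo group held constant, pentylamino in place of isopropyl on a carbonyl carbon therefore keeps the two numbers within the scatter of each other, even though this change brings in a longer chain and a hydrogen-bond donor. Nothing available offers an account of this result.

Going by these compounds, whether a shorter chain such as ethylamino, a phenylamino group or a carboxylic acid at the end of the pentyl chain would also stay within the scatter remains open. Also open, on these data alone, is whether pentylamino on the carbonyl carbon would give the same result with isopropyl in place of iodo on the aromatic carbon.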